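Swapping a dimethylamino for an isopropylamino on a fused core

The source may report more compounds than this note shows. Statements on the series, on what has been measured and on what is new or still open speak of the compounds shown alone.

Within the data shown here, compound 2 `CN(C)c1nc(Nc2ccc(C(F)(F)F)cc2)c2nc(Nc3c(Cl)cccc3Cl)sc2n1` stands at the low end of the two numbers recorded so far: in a functional assay on HEK293 cells for antagonist activity at transient receptor potential cation channel subfamily V member 1 (Homo sapiens), read by calcium flux (a higher number here means a weaker inhibitor, a lower number a stronger inhibitor), compound 2 gives 59 nM, while compound 1 `CC(C)N1CCN(c2nc(Nc3ccc(C(F)(F)F)cc3)c3nc(Nc4c(Cl)cccc4Cl)sc3n2)CC1` gives 184 nM, and the only measured step, a 3.1-fold lower number from compound 1 to compound 2 (0.49 log units; beyond the scatter), separates them. Compound 3 `CC(C)Nc1nc(Nc2ccc(C(F)(F)F)cc2)c2nc(Nc3c(Cl)cccc3Cl)sc2n1` is not yet measured; it differs from compound 2 by isopropylamino in place of dimethylamino on an aromatic carbon, the new group carrying one hydrogen-bond donor where the old one had none. Among the measured compounds shown here, no measured step exchanges these two groups directly; the one step at this same position, a 3.1-fold lower number from compound 1 to compound 2 (0.49 log units; beyond the scatter), was modest, which suggests the place tolerates variation without large swings. Compound 3 is therefore expected to sit close to compound 2, with a step of a 1.2-fold higher number from compound 2 to compound 3 (0.07 log units; within the scatter) that may not clear the scatter. The estimate for compound 3 in this assay is 70 nM, within a range from 25 nM to 200 nM.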

Compound 3, half-maximal inhibitory concentration: 13 nM
The estimate for compound 3 lay 5.4-fold (0.73 log units) above the measured number; the whole stated range lies above it.
By their numbers in this assay, from the lowest: compound 3; then compound 2; then compound 1.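

In this assay, among these compounds, this position, on an aromatic carbon between two ring nitrogen atoms, proves more responsive than the single earlier step showed: a 4.5-fold lower number from compound 2 to compound 3 (0.66 log units; beyond the scatter), from exchanging dimethylamino for isopropylamino alone. Across the groups shown, the change from a 4-isopropylpiperazin-1-yl group gives a 14-fold lower number from compound 1 to compound 3 (1.15 log units; beyond the scatter), a large step at one place on the shared core. The isopropylamino swap alters the hydrogen-bond donor count and the heavy-atom count together, and nothing shown here accounts for the gain.

On these data alone, it remains open whether the gain depends on the amine hydrogen, which a methoxy group at this place could begin to test, and whether ethylamino or cyclopropylamino would hold it. The compounds shown also leave open whether the same swap would give a similar step with other groups elsewhere on the shared core.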